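Working notes: from compound 2 to compound 4

The source may report more compounds than this note shows. Statements on the series, on what has been measured and on what is new or still open speak of the compounds shown alone.

Values in a functional assay on A-375 cells (Homo sapiens) for cytotoxicity, read by MTT assay, with a stated time of 72 h; on this read-out higher numbers stand for weaker inhibition and lower numbers for stronger inhibition:
- compound 1 `O=C1c2c[n+]([O-])c3ccccc3c2C(=O)c2c1c1ccccc1n2CCCCn1ccnc1`: 350 nM
- compound 2 `O=C1c2c[n+]([O-])c3ccccc3c2C(=O)c2c1c1ccccc1n2Cc1cn([C@@H]2C[C@H](O)[C@@H](CO)O2)nn1`: 20 nM
- compound 3 `CN1CCN(CCCCn2c3c(c4ccccc42)C(=O)c2c[n+]([O-])c4ccccc4c2C3=O)CC1`: 30 nM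

Compound 2 and compound 3 lie within the scatter of each other, and both stand well under compound 1. Compound 4 `CC1(C)O[C@@H](CO)[C@H](Cn2cc(Cn3c4c(c5ccccc53)C(=O)c3c[n+]([O-])c5ccccc5c3C4=O)nn2)O1` is the next case, with this change from compound 2: (5-(hydroxymethyl)-2,2-dimethyl-1,3-dioxolan-4-yl)methyl in place of 4-hydroxy-5-(hydroxymethyl)oxolan-2-yl on an aromatic nitrogen. Among the compounds with values here, the only measured step, a 12-fold lower number from compound 1 to compound 3 (1.07 log units; beyond the scatter), is large, but it concerns a different group on a saturated chain, so no measured step covers this exchange. In this assay a moderate step toward a higher number is expected, as compound 2 at 20 nM already sits at the low end of the values. The expected step is a 3.0-fold higher number from compound 2 to compound 4 (0.48 log units; beyond the scatter), and it remains uncertain. For compound 4 the estimated value is 60 nM, with an expected range from 15 nM to 250 nM.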

Compound 4, half-maximal inhibitory concentration: 190 nM
The estimate for compound 4 lay 3.2-fold (0.50 log units) below the measured number; low and high end bracket the measured number.
By their numbers in this assay, from the lowest: compounds 2 and 3 (each within the scatter of the next); then compounds 4 and 1 (each within the scatter of the next).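

In this assay, the group on the aromatic nitrogen of the five-membered aromatic ring with 3 nitrogen affects the read-out: (5-(hydroxymethyl)-2,2-dimethyl-1,3-dioxolan-4-yl)methyl in place of 4-hydroxy-5-(hydroxymethyl)oxolan-2-yl gives a 9.5-fold higher number from compound 2 to compound 4 (0.98 log units; beyond the scatter). The exchange changes the ring, the heavy-atom count, the hydrogen-bond donor count and the defined stereocentres at once, and the step cannot be divided among them. No available evidence bears on this result. Open, as far as these compounds go, is how a simple hydroxyethyl chain, an amine or a carboxylic acid on that nitrogen would compare with compound 2.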